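This account rests on a few compounds, and the source may have more. Where it says the series, first, only, none or still open, it means among the compounds named here.

Compound 1, `Cc1nc(C(NC(=O)C(=O)Nc2ccc(F)cc2F)C2CCCCN2)sc1CO`, was run in an ADME assay on MT2 cells (Homo sapiens) for cytotoxicity, read by XTT assay, with a stated time of 4 days; a higher number here means that more compound is tolerated, a lower number that less compound is tolerated. In this assay compound 1 yields only a limit, > 110000 nM. Compound 2, `Cc1nc(C(NC(=O)C(=O)Nc2ccc(F)cc2F)C2CCCCN2)sc1CCO`, also stops at a limit in this assay, > 105000 nM. Compound 3, `CC(=O)N1CCCCC1C(NC(=O)C(=O)Nc1ccc(Cl)cc1)c1nc(C)c(CCO)s1`, likewise gives no number but a limit in this assay, > 84000 nM. Going by the values given here, compound 1 therefore stands at one of three limits, with no measured number among them; the limit of > 110000 nM in this assay, at which 1 of the 3 values shown sits, and the limit of > 105000 nM in this assay, at which 1 of the 3 values shown sits, together leave a step that the two limits leave unreadable from compound 1 to compound 2, and that is the only measured step in the set. Compound 4, `Cc1ccc(NC(=O)C(=O)NC(c2nc(C)c(CO)s2)C2CCCCN2)c(F)c1`, differs from compound 1 by methyl in place of fluoro on an aromatic carbon. Among the compounds with values here, no measured step touches that part of the structure, and the one step that exists cannot be sized, so nothing here argues for a shift beyond the scatter in this assay. Compound 4 is accordingly expected to sit at a limit as well, the step from compound 1 to compound 4 being estimated as a number no higher from compound 1 to compound 4 (the limit leaves the size open). The estimate for compound 4 in this assay is 110000 nM, within 60000 nM to 200000 nM, and most probably reported once more only as a limit.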

Compound 4, half-maximal cytotoxic concentration: > 109000 nM
Compound 4 ended at the assay's limit; the forecaster's own chance of this, stated with the estimate: 85%; the middle value is on the limit's open side.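

Compound 1 and compound 4 each give only a limit in this assay, so the step between them, methyl in place of fluoro on an aromatic carbon, cannot be read. The compounds shown leave open where any of them would reach half-maximal cytotoxicity, and whether any structural change shifts that concentration.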